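This account rests on a few compounds, and the source may have more. Where it says the series, first, only, none or still open, it means among the compounds named here.

Working notes on the sulfonyl series.

Compound 1 `O=C(NCc1ccc(S(=O)(=O)c2cccc(C(F)(F)F)c2)cc1)N1Cc2ccncc2C1` is the reference point. Among the measured compounds shown here, in a functional assay on A2780 cells (Homo sapiens) for cytotoxicity, read by sulforhodamine B assay, with a stated time of 72 h (on this read-out lower numbers stand for stronger inhibition and higher numbers for weaker inhibition), compound 1 gives 2.7 nM, the lowest of the three numbers measured so far. Compound 2 `O=C(NCc1ccc(S(=O)(=O)C2CCOCC2)cc1)N1Cc2ccncc2C1` gives 35 nM and compound 3 `O=C(NCc1ccc(S(=O)(=O)C2CCCOC2)cc1)N1Cc2ccncc2C1` gives 32 nM. Both changes swap the aryl group on the sulfonyl sulfur for a six-membered non-aromatic ring holding one oxygen: a 13-fold higher number from compound 1 to compound 2 (1.11 log units; beyond the scatter) and a 12-fold higher number from compound 1 to compound 3 (1.07 log units; beyond the scatter). Between the two oxanyl compounds there is nothing to separate, as a 1.1-fold lower number from compound 2 to compound 3 (0.04 log units; within the scatter) shows.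

Compound 4 `O=C(NCc1ccc(S(=O)(=O)C2CCN(C3COC3)CC2)cc1)N1Cc2ccncc2C1` is not yet measured. The change from compound 1 is 1-(oxetan-3-yl)piperidin-4-yl in place of 3-(trifluoromethyl)phenyl on a sulfonyl sulfur. As with compounds 2 and 3, a six-membered non-aromatic ring takes the place of the aryl group on the sulfonyl sulfur, so the two large steps above bear directly on this one. A loss of similar size is expected, and compound 4 is therefore estimated at 40 nM (range 12 nM to 130 nM), which corresponds to an expected step of a 15-fold higher number from compound 1 to compound 4 (1.17 log units; beyond the scatter). For the measured compounds named here, the added oxetanyl-bearing ring nitrogen has no precedent in the set, so the range is kept wide.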

Compound 4, half-maximal inhibitory concentration: 7.4 nM
Compound 4: the middle estimate sits 5.4-fold (0.73 log units) above what was measured; measured number below the stated range.
By their numbers in this assay, from the lowest: compound 1; then compound 4; then compounds 3 and 2 (each within the scatter of the next).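

In this assay a six-membered non-aromatic ring on the sulfonyl sulfur does not in itself bring a large loss, since the 1-(oxetan-3-yl)piperidin-4-yl group gives a 2.7-fold higher number from compound 1 to compound 4 (0.44 log units; beyond the scatter) as a modest step and compound 1 still holds the lowest number. What the ring carries matters at this position: there is a 4.3-fold lower number from compound 3 to compound 4 (0.64 log units; beyond the scatter) and a 4.7-fold lower number from compound 2 to compound 4 (0.67 log units; beyond the scatter) in favour of the 1-(oxetan-3-yl)piperidin-4-yl group, whereas the two oxanyl groups could not be separated. No measured data account for this difference between the non-aromatic groups.

As far as these compounds go, it remains open whether the ring nitrogen or the oxetan-3-yl group on it carries the difference from the oxanyl compounds. A piperidin-4-yl group with a free secondary amine, or with a methyl on the nitrogen, would bear on that question.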